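This account rests on a few compounds, and the source may have more. Where it says the series, first, only, none or still open, it means among the compounds named here.

Measured in a functional assay on Jurkat cells (Homo sapiens) for inhibition, read by MTT assay, with a stated time of 72 h (a lower number here means a stronger inhibitor of growth, a higher number a weaker inhibitor of growth), so far:
Compound 1 `O=C1CC(N2C(=O)CSC2=S)C(=O)N1c1ccc(Cl)cc1` gives 88400 nM
Compound 2 `O=C1CC(N2C(=O)CSC2=S)C(=O)N1c1ccc(O)cc1` gives 23400 nM
Compound 3 `O=C1CC(N2C(=O)/C(=C/C(Cl)=C/c3ccc([N+](=O)[O-])cc3)SC2=S)C(=O)N1c1ccc(Cl)cc1` gives 3400 nM

Of these three, compound 3 has the lowest number, and its value stands apart from those of compound 1 and compound 2 by more than the scatter. Compound 4 `O=C1CC(N2C(=O)/C(=C/C(Cl)=C/c3ccc([N+](=O)[O-])cc3)SC2=S)C(=O)N1c1ccc(O)cc1` has yet to be measured and differs from compound 3 in one place. The difference is hydroxy in place of chloro on an aromatic carbon and amounts to hydroxy in place of chloro on an aromatic carbon, which turns 4-chlorophenyl into 4-hydroxyphenyl. For the measured compounds named here, only one measured step bears on this change, the same exchange taken a 3.8-fold lower number from compound 1 to compound 2 (0.58 log units; beyond the scatter) in the smaller compounds. Neither compound 1 nor compound 2 carries the extended group that compound 3 bears on the core, and a single pair cannot show whether the step transfers in full. A lower number is therefore expected in this assay for compound 4, by a similar or somewhat smaller margin. The estimated step is a 2.6-fold lower number from compound 3 to compound 4 (0.42 log units; beyond the scatter) in this expectation. Compound 4 is expected at 1300 nM with an estimated range from 450 nM to 3800 nM when measured.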

Compound 4, concentration for 50% growth inhibition: 1300 nM
Compound 4: middle estimate and measured number agree at the digits printed; the measured number falls inside the stated range.
By their numbers in this assay, from the lowest: compound 4; then compound 3; then compound 2; then compound 1.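

The exchange of 4-chlorophenyl for 4-hydroxyphenyl keeps its direction on the larger compounds in this assay, with a 2.6-fold lower number from compound 3 to compound 4 (0.42 log units; beyond the scatter). The change therefore no longer rests on a single pair, and the extended group carried on the core by compound 3 and compound 4 does not abolish it. The two steps also cannot be told apart in size: the same change on two cores in this assay, a 3.8-fold lower number (0.58 log units; beyond the scatter) from compound 1 to compound 2 and a 2.6-fold lower number (0.42 log units; beyond the scatter) from compound 3 to compound 4, 1.4-fold (0.16 log units) apart, within the scatter of two such steps

The compounds shown leave open whether another group at this place on the aromatic ring, such as methoxy or an amine, would follow hydroxy, and whether fluoro would follow chloro. On these data alone, it also remains open whether the same step would appear if the extended group ended in a carboxylic acid rather than a nitro group.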